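A few compounds are considered here, and "the series" means these few. Any claim that something is new, unique, unknown or untested is made for them only; others in the source may bear on it.

In a functional assay on MT2 cells (Homo sapiens) for cytotoxicity, read by XTT assay, with a stated time of 3 days (on this read-out higher numbers stand for lower toxicity in this test and lower numbers for higher toxicity in this test), the three measured compounds stand as follows.

Compound 1, `COc1cnc(-n2cc(C)cn2)c2[nH]cc(C(=O)C(=O)N3CCN(C(=O)c4ccccc4)CC3)c12`: 243000 nM.
Compound 2, `COc1cnc(-n2cnc(C(=O)N(C)C)n2)c2[nH]cc(C(=O)C(=O)N3CCN(C(=O)c4ccccc4)CC3)c12`: > 300000 nM, which is a limit of the assay and not a number.
Compound 3, `CCCSc1ncn(-c2ncc(OC)c3c(C(=O)C(=O)N4CCN(C(=O)c5ccccc5)CC4)c[nH]c23)n1`: 7000 nM.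

Compound 1 holds the highest of the two real numbers; its nearest neighbour is compound 3, reached by a 35-fold lower number from compound 1 to compound 3 (1.54 log units; beyond the scatter). Compound 2 sits at the assay limit (the limit of > 300000 nM in this assay, at which 1 of the 3 values shown sits), so its step from compound 1, an at least 1.2-fold higher number from compound 1 to compound 2 (0.09 log units; that floor lies within the scatter), is only a floor.

The unmeasured compound 4, `CCCS(=O)(=O)c1ncn(-c2ncc(OC)c3c(C(=O)C(=O)N4CCN(C(=O)c5ccccc5)CC4)c[nH]c23)n1`, differs from compound 1 in one place: 3-(propylsulfonyl)-1H-1,2,4-triazol-1-yl in place of 4-methyl-1H-pyrazol-1-yl on an aromatic carbon. Among the measured compounds shown here, two measured steps bear on this change. Going to the propylsulfanyl analogue gave a 35-fold lower number from compound 1 to compound 3 (1.54 log units; beyond the scatter), and within the triazole pair an at least 42-fold lower number from compound 2 to compound 3 (1.63 log units; beyond the scatter), both large. For the measured compounds named here, compound 4 shares the triazole ring and the propyl chain of compound 3 but carries a propylsulfonyl group, which appears in none of the measured compounds, so the data do not fix the size of its step. A lower number than compound 1 is expected, though smaller than the step seen to compound 3; the expected step is a 6.1-fold lower number from compound 1 to compound 4 (0.78 log units; beyond the scatter). Compound 4 is estimated at 40000 nM, with a range from 6000 nM to 250000 nM.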

Compound 4, half-maximal cytotoxic concentration: 207000 nM
Compound 4: middle estimate off by 5.2-fold (0.71 log units), on the low side; low and high end bracket the measured number.
By their numbers in this assay, from the lowest: compound 3; then compounds 4 and 1 (each within the scatter of the next). At a limit, above all of these: compound 2.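

Replacing 4-methyl-1H-pyrazol-1-yl with 3-(propylsulfonyl)-1H-1,2,4-triazol-1-yl on an aromatic carbon next to the ring nitrogen and para to a methoxy group gives, in this assay, a 1.2-fold lower number from compound 1 to compound 4 (0.07 log units; within the scatter), so this assay does not separate the two groups at this position. The sulfur-bearing side chain matters far more, since changing only propylsulfanyl to propylsulfonyl gives a 30-fold higher number from compound 3 to compound 4 (1.47 log units; beyond the scatter), so among these compounds the triazole ring and propyl chain do not by themselves bring the higher toxicity of compound 3. The value for compound 2 is a limit and not a number, so the step, an at least 1.4-fold lower number from compound 2 to compound 4 (0.16 log units; that floor lies within the scatter), is only a floor: the limit of > 300000 nM in this assay, at which 1 of the 4 values shown sits.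

The compounds shown leave open whether the low number of compound 3 depends on the propyl chain, as a methylsulfanyl group or a longer chain on the sulfur could show. They also leave open how an amine or a carboxylic acid on the triazole would behave at this position.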